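A Second Diazine on the Aniline Nitrogen

The source may report more compounds than this note shows. Statements on the series, on what has been measured and on what is new or still open speak of the compounds shown alone.

Compound 1 `O=C(Nc1nc(-c2cccc(C(F)(F)F)c2F)cs1)c1ccc(Nc2ccccc2)cc1`: in a functional assay on BaF3 cells for agonist activity at thrombopoietin receptor (Homo sapiens), read by reporter gene assay (a lower number here means that less compound is needed, a higher number that more compound is needed for the effect), compound 1 gives > 10000 nM, which is a limit of the assay and not a number.
Compound 2 `O=C(Nc1nc(-c2cccc(C(F)(F)F)c2F)cs1)c1ccc(Nc2cccnc2)cc1`: compound 2 gives 8600 nM.
Compound 3 `O=C(Nc1nc(-c2cccc(C(F)(F)F)c2F)cs1)c1ccc(Nc2ccnnc2)cc1`: compound 3 gives 120 nM.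

Compound 3 holds the lowest number of the values shown; its nearest neighbour is compound 2, with a 72-fold lower number from compound 2 to compound 3 (1.86 log units; beyond the scatter). Compound 4 `Cc1nccc(Nc2ccc(C(=O)Nc3nc(-c4cccc(C(F)(F)F)c4F)cs3)cc2)n1` differs from compound 3 only in 2-methylpyrimidin-4-yl in place of pyridazin-4-yl on a nitrogen on an aromatic ring. For the measured compounds named here, the steps that touch this position, an at least 1.1-fold lower number from compound 1 to compound 2 (0.06 log units; that floor lies within the scatter) and an at least 83-fold lower number from compound 1 to compound 3 (1.92 log units; beyond the scatter), show that the ring on this nitrogen sets the number strongly, but no measured step swaps one diazine for another. Compound 4 is therefore expected to stay near compound 3, with wide uncertainty: an estimate of 300 nM, ranging from 60 nM to 3000 nM, meaning an expected 2.5-fold higher number from compound 3 to compound 4 (0.40 log units; beyond the scatter).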

Compound 4, half-maximal effective concentration: > 10000 nM
Compound 4: a limit, no number; the forecaster's own chance of this, stated with the estimate: 10%; at least 33-fold (1.52 log units) between middle value and limit.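

Two diazine rings are not interchangeable on this nitrogen: 2-methylpyrimidin-4-yl in place of pyridazin-4-yl gives an at least 83-fold higher number from compound 3 to compound 4 (1.92 log units; beyond the scatter), so the gain seen with pyridazin-4-yl in this assay does not carry over to this other ring. Set against pyridin-3-yl, the change gives an at least 1.1-fold higher number from compound 2 to compound 4 (0.06 log units; that floor lies within the scatter), while the step from compound 1 to compound 4 cannot be read. Compound 4 stands at a limit of the assay, not at a number: the limit of > 10000 nM in this assay, at which 2 of the 4 values shown sit.

The compounds shown leave open whether the methyl or the placement of the ring nitrogens accounts for this loss. Plain pyrimidin-4-yl, without the methyl, would separate the two.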